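This account rests on a few compounds, and the source may have more. Where it says the series, first, only, none or still open, it means among the compounds named here.

Measured in an ADME assay; on this read-out higher numbers stand for a longer-lived compound and lower numbers for a shorter-lived compound:

- compound 1 `COc1ccc(C[S+]([O-])c2ncccc2C(=O)Nc2ccncc2)c(OC)c1` gives 0.84 h
- compound 2 `COc1cccc(OC)c1C[S+]([O-])c1ncccc1C(=O)Nc1ccncc1` gives 38.5 h

Of these two numbers, compound 2 holds the higher one, and compound 1 lies below it by a margin well beyond the scatter of repeated measurements. The next compound to be read in this assay is compound 3 `COc1cc(OC)c(C[S+]([O-])c2ncccc2C(=O)Nc2ccncc2)c(OC)c1`, which departs from compound 2 at one place: methoxy in place of hydrogen on an aromatic carbon. Methoxy takes the place of hydrogen on an aromatic carbon, meta to two methoxy groups and para to a large group.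

Going by the values given here, no measured pair isolates a change of this kind, so the size of the step cannot be read directly from the data. Among the compounds with values here, the only guide is the wide gap between compound 1 at 0.84 h and compound 2 at 38.5 h, which shows that numbers can differ greatly. A fall is judged more likely than a rise, and it is expected to lie beyond the scatter, though only modestly so. The estimated change is a 4.8-fold lower number from compound 2 to compound 3 (0.68 log units; beyond the scatter) in this reading. Compound 3 is expected at 8 h, with an estimated range from 1.2 h to 40 h.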

Compound 3, half-life: < 0.03 h
Compound 3 ended at the assay's limit (the forecaster's own chance of this, stated with the estimate: 3%); middle value at least 260-fold (2.42 log units) from the limit.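

In this assay, going by these compounds alone, methoxy in place of hydrogen on an aromatic carbon, meta to two methoxy groups and para to a large group, comes with an at least 1200-fold lower number from compound 2 to compound 3 (3.10 log units; beyond the scatter), so this single position can carry a very large drop in half-life, which no earlier pair could show. The step to compound 3 from the other earlier compound is also large, an at least 28-fold lower number from compound 1 to compound 3 (1.44 log units; beyond the scatter), which places compound 3 lower than both earlier compounds, including the one with the shorter half-life. The reading for compound 3 is a limit of the assay and not a number, so both steps give only the least size of the drop: the limit of < 0.03 h in this assay, at which 1 of the 3 values shown sits.

The compounds shown leave open whether this drop belongs to methoxy itself or would appear with any group on this aromatic carbon, a question that fluorine, a hydroxyl group or an amine at the same place would address. They also leave open how far below the limit compound 3 truly lies, and whether a longer chain such as ethoxy at this place would behave in the same way.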